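A few compounds are considered here, and "the series" means these few. Any claim that something is new, unique, unknown or untested is made for them only; others in the source may bear on it.

Measured in a functional assay on HepG2 cells (Homo sapiens) for inhibition, read by MTT assay, with a stated time of 48 h; on this read-out lower numbers stand for stronger inhibition of growth and higher numbers for weaker inhibition of growth:
- compound 1 `Cn1cc(C2CC(c3ccccc3)=NN2C(=O)c2cccnc2Cl)c2ccccc21`: > 10000 nM (a limit, not a number)
- compound 2 `COc1cc(C2=NN(C(=O)c3ccc(C)nc3)C(c3cn(C)c4ccccc34)C2)cc(OC)c1OC`: 310 nM
- compound 3 `COc1ccc2c(c1)c(C1CC(c3ccc(Cl)cc3)=NN1C(=O)c1ccc(OC)nc1)cn2C`: 2080 nM

Of the two actual numbers in this assay, compound 3 has the higher, and its gap from compound 2 lies beyond the scatter. The remaining entry, for compound 1, is a limit and cannot be placed on the same scale.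

The next analogue is compound 4 `COc1ccc2c(c1)c(C1CC(c3cc(OC)c(OC)c(OC)c3)=NN1C(=O)c1ccc(OC)nc1)cn2C`, which has 3,4,5-trimethoxyphenyl in place of 4-chlorophenyl on a carbon with a double bond to nitrogen. Within the data shown here, no step between measured compounds isolates this change, so any expectation is indirect. The closest guide is compound 2, which also carries 3,4,5-trimethoxyphenyl on that carbon and gives 310 nM. However, compound 2 also differs from compound 3 elsewhere, so the gap between their values cannot be assigned to this group alone. A step towards stronger inhibition of growth is therefore expected, probably stopping short of the full gap between those two values. The estimated change is a 4.2-fold lower number from compound 3 to compound 4 (0.62 log units; beyond the scatter). For compound 4 the expected value is 500 nM, with an estimated range of 120 nM to 2200 nM.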

Compound 4, concentration for 50% growth inhibition: > 10000 nM
Compound 4: no number, only a limit (the forecaster's own chance of this, stated with the estimate: 3%); middle value at least 20-fold (1.30 log units) away from the limit.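

In this assay, among these compounds, the one readable change at this position, on a carbon with a double bond to nitrogen of the five-membered ring, is 3,4,5-trimethoxyphenyl in place of 4-chlorophenyl, and it gives an at least 4.8-fold higher number from compound 3 to compound 4 (0.68 log units; beyond the scatter), a move towards weaker inhibition of growth. Compound 4 stands at > 10000 nM, which is a limit and not a number, so the step sets only a lower bound on the loss: the limit of > 10000 nM in this assay, at which 2 of the 4 values shown sit.

The 3,4,5-trimethoxyphenyl group therefore does not carry strong inhibition of growth by itself, although compound 2, which also bears it, gives 310 nM; compound 2 differs from compound 4 in more than one place, so the pair cannot assign this contrast to any single change.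

Still open, as far as these compounds go, is whether the methoxy groups on the ring as a whole go with the weaker inhibition of growth, or whether a smaller group such as 4-methoxyphenyl, or an amine such as 4-aminophenyl, would hold a number on the core of compound 3. Also open, from the compounds shown here alone, is which of the other differences in compound 2 matters when 3,4,5-trimethoxyphenyl is present.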